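Swapping the amide substituent on a furoxan-bearing coumarin amide

A few compounds are considered here, and "the series" means these few. Any claim that something is new, unique, unknown or untested is made for them only; others in the source may bear on it.

Among the compounds with values here, compound 2 `COc1cc2cc(C(=O)NCCCc3ccc(F)cc3)c(=O)oc2cc1OCCCOc1no[n+]([O-])c1S(=O)(=O)c1ccccc1` gives 690 nM in a functional assay on MDA-MB-231 cells (Homo sapiens) for inhibition, read by MTT assay, with a stated time of 48 h (on this read-out lower numbers stand for stronger inhibition and higher numbers for weaker inhibition), the lowest of the two numbers so far; compound 1 `COc1cc2cc(C(=O)Nc3ccccc3)c(=O)oc2cc1OCCCOc1no[n+]([O-])c1S(=O)(=O)c1ccccc1` gives 1190 nM in this assay, and the two lie within the scatter. Compound 3 `COc1ccc(NC(=O)c2cc3cc(OC)c(OCCCOc4no[n+]([O-])c4S(=O)(=O)c4ccccc4)cc3oc2=O)cc1` carries 4-methoxyphenyl in place of 3-(4-fluorophenyl)propyl on an amide-type nitrogen. Within the data shown here, the only step that bears on this change is a 1.7-fold lower number from compound 1 to compound 2 (0.24 log units; within the scatter), which brought an aryl amide to the longer chain without a shift beyond the scatter. Returning to an aryl amide in compound 3 is therefore expected to give a step of about a 1.4-fold higher number from compound 2 to compound 3 (0.16 log units; within the scatter), back toward where compound 1 stands, with no movement beyond the scatter. Compound 3 is estimated at 1000 nM, with a range of 400 nM to 2500 nM.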

Compound 3, half-maximal inhibitory concentration: 730 nM
For compound 3 the middle estimate is 1.4-fold (0.14 log units) above the measured one; the measured number falls inside the stated range.
By their numbers in this assay, from the lowest: compounds 2, 3 and 1 (each within the scatter of the next).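

In this assay, 4-methoxyphenyl in place of 3-(4-fluorophenyl)propyl on the amide-type nitrogen gives a 1.1-fold higher number from compound 2 to compound 3 (0.02 log units; within the scatter), and methoxy in place of hydrogen on an aromatic carbon gives a 1.6-fold lower number from compound 1 to compound 3 (0.21 log units; within the scatter). This position has now carried three different groups, an unsubstituted phenyl, a substituted phenyl and a longer chain, with all three compounds within the scatter of one another. No measurement offered here explains this. Going by these compounds, whether a chain ending in an amine or a carboxylic acid on this nitrogen would move the number beyond the scatter remains open.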